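Lengthening the amide side chain toward an aromatic end

This account rests on a few compounds, and the source may have more. Where it says the series, first, only, none or still open, it means among the compounds named here.

Compound 1 `CCCSc1nc(Cl)c2c(n1)N(Cc1ccccc1)C(C(=O)NCCC1=CCc3ccccc31)N2` gives 27000 nM in a functional assay on MGC-803 cells (Homo sapiens) for antiproliferative activity, read by MTT assay, with a stated time of 72 h; on this read-out higher numbers stand for weaker inhibition and lower numbers for stronger inhibition.
Compound 2 `CCCSc1nc(Cl)c2c(n1)N(Cc1ccccc1)C(C(=O)N1CCN(C)CC1)N2` reaches only the limit of this assay, > 64000 nM.
Compound 3 `CCCSc1nc(Cl)c2c(n1)N(Cc1ccccc1)C(C(=O)NCC(C)C)N2` gives 58400 nM in this assay.

Among the two compounds with an actual number, compound 3 holds the higher one, so it is the weaker of that pair; compound 2 stands at a limit and cannot be ranked. The new compound 4 `CCCSc1nc(Cl)c2c(n1)N(Cc1ccccc1)C(C(=O)NCCCc1ccccc1)N2` differs from compound 3 in one place: phenethyl in place of isopropyl on a saturated chain carbon bound to an amide-type nitrogen. For the measured compounds named here, one measured step bears on this directly: a 2.2-fold higher number from compound 1 to compound 3 (0.34 log units; beyond the scatter), where removing a large ring-bearing group from the same chain position made the number rise. Compound 4 restores part of that, an aromatic ring on the chain, so a move back down is expected. The other step, an at least 1.0-fold lower number from compound 2 to compound 3 (0.03 log units; that floor lies within the scatter), concerns the opposite side of the amide and rests on a limit (the limit of > 64000 nM in this assay, at which 1 of the 3 values shown sits), so it offers little guidance. Compound 4 is therefore expected to show a modestly lower number, about a 1.9-fold lower number from compound 3 to compound 4 (0.29 log units; within the scatter). The estimate for compound 4 in this assay is 30000 nM, with a likely range from 12000 nM to 70000 nM.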

Compound 4, half-maximal inhibitory concentration: 16900 nM
For compound 4 the middle estimate is 1.8-fold (0.25 log units) above the measured one; the range from low to high includes it.
By their numbers in this assay, from the lowest: compounds 4 and 1 (each within the scatter of the next); then compound 3. At a limit, above all of these: compound 2.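

Within this assay, placing phenethyl instead of isopropyl on the side chain gives a 3.5-fold lower number from compound 3 to compound 4 (0.54 log units; beyond the scatter), so a plain phenyl ring at the end of the chain is enough to lower the number. Dropping the five-membered non-aromatic ring of the larger side chain brings no readable change (a 1.6-fold lower number from compound 1 to compound 4 (0.20 log units; within the scatter)). (Compound 2 stands at a limit, so an at least 3.7-fold lower number from compound 2 to compound 4 (0.57 log units; beyond the scatter) is only a floor: the limit of > 64000 nM in this assay, at which 1 of the 4 values shown sits).

From the compounds shown here alone, what a longer chain such as 4-phenylbutyl would do remains open, as does an amine or a carboxylic acid at the chain end in place of the phenyl ring. A 3-cyclohexylpropyl chain would also be needed to tell whether the aromatic ring matters or only the added carbons do.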